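Two Hydroxyls Added to a Benzylamine Side Chain

The source may hold more compounds than are shown below. What is called first, only, known or untested is meant among the compounds shown, and "the series" means these compounds.

Of the compounds shown here, two sharing the same core have been measured so far. Compound 1 `C=C1CC[C@@H]2[C@](C)(CO)[C@H](O)CC[C@@]2(C)[C@@H]1C/C=C1\C=COC1=O` and compound 2 `C=C1CC[C@@H]2[C@](C)(CNCc3ccccc3)[C@H](O)CC[C@@]2(C)[C@@H]1/C=C/C1=CCOC1=O` were both tested in a functional assay on BMMC cells (Mus musculus, strain C57BL/6) for inhibition, with stated times of 5 days and 48 h; on this read-out higher numbers stand for weaker inhibition and lower numbers for stronger inhibition. In this assay compound 1 gives 2770 nM and compound 2 gives 960 nM. Within the data shown here, compound 2 therefore stands at the lower, stronger end of the two numbers, and the only neighbour, compound 1, sits well beyond the scatter above it.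

The next compound, compound 3 `C=C1CC[C@@H]2[C@](C)(CNCc3ccc(O)c(O)c3)[C@H](O)CC[C@@]2(C)[C@@H]1/C=C/C1=CCOC1=O`, has not yet been measured. It differs from compound 2 in one place: 3,4-dihydroxyphenyl in place of phenyl on a saturated chain carbon bound to an amine nitrogen. Among the measured compounds shown here, no measured pair shows what such a change does on this core, so the expectation rests on the change alone and on where compound 2 already stands.

A small step is expected, pointing toward a somewhat lower number but possibly staying within the scatter; the estimated step of a 1.3-fold lower number from compound 2 to compound 3 (0.11 log units; within the scatter) reflects that. Compound 3 is expected to give about 750 nM in this assay, with a plausible range from 300 nM to 2200 nM.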

Compound 3, half-maximal inhibitory concentration: 9440 nM
Compound 3: middle estimate off by 13-fold (1.10 log units), on the low side; measured number outside the range, above it.
By their numbers in this assay, from the lowest: compound 2; then compound 1; then compound 3.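

This position on the benzylamine side chain is sensitive to what its aromatic ring carries: in this assay, 3,4-dihydroxyphenyl in place of phenyl gives a 9.8-fold higher number from compound 2 to compound 3 (0.99 log units; beyond the scatter), a step beyond the scatter and toward weaker inhibition. Until now, no pair on the shared core had shown what any change at this place does, and this first pair shows that a change on the ring alone, which brings in 2 hydrogen-bond donors and 2 hydrogen-bond acceptors, can take away much of the inhibition seen with compound 2. The cause of this loss cannot be told from what is available here.

From the compounds shown here alone, it remains open whether a ring with a single hydroxyl, or with methoxy groups in place of the two hydroxyls, would give a number close to that of compound 2 or close to that of compound 3. Going by these compounds, it is equally open whether a fluorine or a carboxylic acid on the same ring would move the number in the same direction, and by how much.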